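Mirror Configuration at One Stereocentre, Half-Life Still Open

The source may report more compounds than this note shows. Statements on the series, on what has been measured and on what is new or still open speak of the compounds shown alone.

In an ADME assay on microsomes from liver (Mus musculus) for metabolic stability, read by LC-MS, using NADPH, with a stated time of 60 min, tested at 1 uM (on this read-out lower numbers stand for a shorter-lived compound and higher numbers for a longer-lived compound), compound 1 (`CCCCCCCC/C=C\CCCCCCCC(=O)N1Cc2ccccc2[C@@H]1C(=O)O`) gives 1.07 h and compound 2 (`CCCCC/C=C\C/C=C\CCCCCCCC(=O)N1Cc2ccccc2[C@H]1C(=O)O`) gives 1.07 h and so stands level with it within the scatter. Compound 3 (`CCCCC/C=C\C/C=C\CCCCCCCC(=O)N1Cc2ccccc2[C@@H]1C(=O)O`) differs from compound 2 as the two compounds have the same atoms and bonds and differ only in configuration as drawn: 1 of 3 stereo elements differ; a stereocentre at a saturated ring carbon is drawn S in compound 2 and R in compound 3 records: a stereocentre at a saturated ring carbon is drawn S in compound 2 and R in compound 3. Within the data shown here, no measured pair isolates such a change, so no step beyond the scatter is expected in this assay. The estimate rests on compound 2 at 1.07 h alone. The expected move is no change at the digits printed from compound 2 to compound 3 (within the scatter) and stays within the scatter. Compound 3 is estimated at 1.07 h with an expected range from 0.6 h to 1.9 h as its bounds.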

Compound 3, half-life: 1.07 h
Beside the measured number, compound 3's estimate shows no gap at the digits printed; the range from low to high includes it.
By their numbers in this assay, from the lowest: compounds 1, 2 and 3 (each within the scatter of the next).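

In this assay, the stereocentre at the saturated ring carbon can now be read on its own, with no change at the digits printed from compound 2 to compound 3 (within the scatter). The pair is a clean test of that one centre: the fact that compounds 2 and 3 differ only in the configuration as drawn. The chain change can also now be read at one drawn configuration, with hept-1-en-1-yl in place of heptyl giving no change at the digits printed from compound 1 to compound 3 (within the scatter).

Going by these compounds, whether the half-life stays this flat with a methyl ester in place of the carboxylic acid remains open. So does whether a longer chain leaves it unchanged.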